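This account rests on a few compounds, and the source may have more. Where it says the series, first, only, none or still open, it means among the compounds named here.

Measured set:
compound 1, `N=C1CCN(S(=O)(=O)c2ccc(NC(=O)c3ccc([N+](=O)[O-])o3)cc2)CC1`, in an ADME assay on IMR-90 cells (Homo sapiens) for cytotoxicity, read by CellTiter-Blue, with a stated time of 46 h; a higher number here means that more compound is needed for the effect, a lower number that less compound is needed: > 25000 nM
compound 2, `O=C(Nc1ccc(S(=O)(=O)N2CCOCC2)cc1)c1ccc([N+](=O)[O-])cc1`, in this assay: > 25000 nM
compound 3, `CC1(C)CCN(S(=O)(=O)c2ccc(NC(=O)c3cccc([N+](=O)[O-])c3)cc2)CC1`, in this assay: > 25000 nM

The value of compound 1 is a limit of the assay, not a number. The value of compound 2 is likewise a limit. Going by the values given here, the value of compound 3 is also a limit, so compound 3 stands at the limit of > 25000 nM in this assay, at which 3 of the 3 values shown sit, and no step between measured compounds can be read from this set. Compound 4, `CC1(C)CCN(S(=O)(=O)c2ccc(NC(=O)c3ccc([N+](=O)[O-])s3)cc2)CC1`, differs from compound 3 in one place: 5-nitrothiophen-2-yl in place of 3-nitrophenyl on a carbonyl carbon. With every measured value at the limit, no step beyond the scatter is expected in either direction. For compound 4 the estimate in this assay is 40000 nM (range 12000 nM to 150000 nM). The step from a step that the limit leaves unreadable from compound 3 to compound 4 is expected to be small, the reading most likely again only a limit.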

Compound 4, half-maximal effective concentration: > 25000 nM
Compound 4 was reported as a limit; the forecaster's own chance of this, stated with the estimate: 80%; the middle value lies beyond the limit too.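

No step can be read from compound 3 to compound 4, as both readings are limits of the assay, not numbers: the limit of > 25000 nM in this assay, at which 4 of the 4 values shown sit.

The compounds shown leave open which structural change, if any, would bring a measurable reading in this assay.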